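Methyl on the ring of compound 3: working notes

A few compounds are considered here, and "the series" means these few. Any claim that something is new, unique, unknown or untested is made for them only; others in the source may bear on it.

Values in a functional assay on the whole organism for agonist activity, with Mus musculus as the target (a lower number here means that less compound is needed, a higher number that more compound is needed for the effect), for the measured compounds:
- Compound 1 `CC(=O)N(C)C(C)C#CCn1cncc1C` reports > 100 mg/kg as a limit of the assay, not a number.
- Compound 2 `COC(=O)N(C)CC#CCn1cncc1C` gives 4.5 mg/kg as its dose.
- Compound 3 `COC(=O)N(C)C(C)C#CCn1ccnc1` gives 6.6 mg/kg as its dose.

For the measured compounds named here, compound 3 and compound 2 lie within the scatter of each other, and they are the only two compounds with a numerical value. The next step leads to compound 4 `COC(=O)N(C)C(C)C#CCn1cncc1C`, with methyl in place of hydrogen on an aromatic carbon of compound 3: methyl in place of hydrogen on an aromatic carbon is the whole change.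

Going by the values given here, no measured step isolates this methyl. The expectation therefore rests on the numbers of compound 2 at 4.5 mg/kg and compound 3 at 6.6 mg/kg in this assay as the nearest values. The expected change a 1.3-fold lower number from compound 3 to compound 4 (0.12 log units; within the scatter) stays within the scatter, with no direction claimed. For compound 4 the estimate is 5 mg/kg with an expected range of 1.5 mg/kg to 20 mg/kg in this reading.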

Compound 4, dose for half-maximal effect: 97 mg/kg
Compound 4: middle estimate off by 19-fold (1.29 log units), on the low side; the measured number lies above the stated range.
By their numbers in this assay, from the lowest: compounds 2 and 3 (each within the scatter of the next); then compound 4. At a limit, above all of these: compound 1.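

In this assay, methyl in place of hydrogen on an aromatic carbon next to the ring nitrogen gives a 15-fold higher number from compound 3 to compound 4 (1.17 log units; beyond the scatter). Methyl in place of hydrogen on the saturated chain carbon gives a 22-fold higher number from compound 2 to compound 4 (1.33 log units; beyond the scatter), so the large loss appears in both steps that lead to the compound carrying both methyls, and the position's tolerance for methyl depends on the chain carbon. Compound 1 gives > 100 mg/kg, a limit of the assay and not a number. Methoxy in place of methyl on a carbonyl carbon gives an at least 1.0-fold lower number from compound 1 to compound 4 (0.01 log units; that floor lies within the scatter), a step that starts from that limit: the limit of > 100 mg/kg in this assay, at which 1 of the 4 values shown sits.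

Open, going by these compounds, is where a compound with hydrogen at both places would stand in this assay. Also open, on these data alone, is whether ethyl or chlorine on the same ring carbon would behave as methyl does, with or without the chain methyl.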